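A few compounds are considered here, and "the series" means these few. Any claim that something is new, unique, unknown or untested is made for them only; others in the source may bear on it.

Series notes. Going by the values given here, compound 2 `C[Si](C)(C)c1cn(C[C@H](O)[C@H]2OC(=O)C(OCc3ccccc3)=C2OCc2ccccc2)nn1` holds the highest number of the two measured so far: in a functional assay on HeLa cells (Homo sapiens) for antiproliferative activity, read by MTT assay, with a stated time of 72 h (a lower number here means a stronger inhibitor, a higher number a weaker inhibitor), compound 2 gives 22300 nM, while compound 1 `O=C1O[C@H]([C@@H](O)Cn2cc(-c3ccc(Br)cc3)nn2)C(OCc2ccccc2)=C1OCc1ccccc1` gives 3910 nM. The change to compound 3 `COc1ccc(-c2cn(C[C@H](O)[C@H]3OC(=O)C(OCc4ccccc4)=C3OCc3ccccc3)nn2)cc1` is a group of 8 heavy atoms (7 carbon, 1 oxygen; one six-membered aromatic ring of carbon only) in place of a group of 4 heavy atoms (3 carbon, 1 silicon; no ring), on an aromatic carbon. Among the compounds with values here, the only measured step that bears on it is a 5.7-fold higher number from compound 1 to compound 2 (0.76 log units; beyond the scatter), which also exchanged a six-membered aromatic ring against the silicon group on that carbon. Reversing that direction, a step downward in this assay of similar size is expected for compound 3, roughly a 5.0-fold lower number from compound 2 to compound 3 (0.70 log units; beyond the scatter). Compound 3 is therefore estimated at 4500 nM, within 1500 nM to 14000 nM.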

Compound 3, half-maximal inhibitory concentration: 16400 nM
Estimate against measurement, compound 3: 3.6-fold (0.56 log units) below; measured number outside the range, above it.
By their numbers in this assay, from the lowest: compound 1; then compounds 3 and 2 (each within the scatter of the next).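

In this assay a six-membered aromatic ring on this aromatic carbon does not by itself lower the number: 4-methoxyphenyl in place of the silicon group gives a 1.4-fold lower number from compound 2 to compound 3 (0.13 log units; within the scatter). What separates the two aryl compounds is methoxy in place of bromo, with a 4.2-fold higher number from compound 1 to compound 3 (0.62 log units; beyond the scatter), so among these compounds the lower number belongs to the bromo compound alone and not to aryl groups in general. No measurement on hand accounts for this difference.

From the compounds shown here alone, whether a plain phenyl, chloro or an amine on that ring would sit with compound 1 or with compound 3 remains open. Also open, going by these compounds, is whether a longer alkyl chain on the aromatic carbon would match the silicon group.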